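A few compounds are considered here, and "the series" means these few. Any claim that something is new, unique, unknown or untested is made for them only; others in the source may bear on it.

Working notes on the cinnamate series

Three members of the series have been measured in a functional assay on EA.hy 926 cells (Homo sapiens) for cytotoxicity, read by MTT assay, with stated times of 24 h and 12 h, tested at 100 uM; on this read-out lower numbers stand for a weaker effect and higher numbers for a stronger effect at the one concentration tested. Compound 1, `COc1ccc(/C=C/C(=O)O)cc1OC(=O)c1nc(C)c(C)nc1C`, gives 216% in this assay. Compound 2, `COc1cc(/C=C/C(=O)O)cc(OC)c1OC(=O)c1nc(C)c(C)nc1C`, gives 163% in this assay. Compound 3, `CCOC(=O)/C=C/c1ccc(OC)c(OC(=O)c2nc(C)c(C)nc2C)c1`, gives 117% in this assay. The difference between the core of compound 1 and the core of compound 2 is not broken down here; their two values simply show compound 1 higher than compound 2, a gap beyond the scatter, and compound 2 higher than compound 3, also beyond the scatter.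

One change occurs twice in the set. From compound 1 to compound 3 the change is ethyl in place of hydrogen on an oxygen next to a carbonyl group, and it gave a step of a number 99 percentage points lower from compound 1 to compound 3 (beyond the scatter). Compound 4, `CCOC(=O)/C=C/c1cc(OC)c(OC(=O)c2nc(C)c(C)nc2C)c(OC)c1`, has not yet been measured in this assay. From compound 2 to compound 4 the change is ethyl in place of hydrogen on an oxygen next to a carbonyl group. The place of the change is the same word for word in both pairs, so it is taken as the same change on a different core.

For the measured compounds named here, the expectation rests on compound 1 and compound 3, because a number 99 percentage points lower from compound 1 to compound 3 (beyond the scatter) is the only measured instance of this change, and on the starting point of compound 2, which gives 163% in this assay. A step of the same direction and similar size is expected from compound 2 to compound 4, a number 78 percentage points lower from compound 2 to compound 4 (beyond the scatter). Compound 4 is therefore estimated at 85%, with a range from 50% to 125%, the uncertainty resting on a single measured precedent.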

Compound 4, a percentage reported as activity, at one concentration (the size of the read-out at that concentration, not a potency): -47%
For compound 4 the middle estimate is 132 percentage points above the measured one; the measured number lies below the stated range.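

Carboxy to ethoxycarbonyl lowers the read-out in this assay on both cores, and with the new step, a number 210 percentage points lower from compound 2 to compound 4 (beyond the scatter), the direction carries over from one core to the other while the size does not: the same change on two cores in this assay, a number 99 percentage points lower (beyond the scatter) from compound 1 to compound 3 and a number 210 percentage points lower (beyond the scatter) from compound 2 to compound 4, 111 percentage points apart, beyond the scatter of two such steps. The size of this step therefore depends on the core in these two pairs, and the step read on the core of compound 1 gave no safe figure for the core of compound 2, where compound 4 ends at -47%. Two pairs do not show which feature of the cores separates the two steps or why they differ, and they give no rule for a third core.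

The compounds shown leave open whether the larger step on the core of compound 2 is tied to ethyl in particular or would also appear with a methyl ester, a longer chain on the same oxygen, or an amide in place of the ester. Going by these compounds, each compound is also read at one concentration only, so these notes say nothing about potency, and whether the gap between the two steps would hold across a range of concentrations remains open.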